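Replacing sec-butoxy on the aromatic ring of compound 3

This account rests on a few compounds, and the source may have more. Where it says the series, first, only, none or still open, it means among the compounds named here.

In a functional assay on the whole organism (strain Sprague-Dawley) for inhibition, with Rattus norvegicus as the target, with a stated time of 10 min (a higher number here means that more compound is needed for the effect, a lower number that less compound is needed), compound 1 (`O=C(O)c1cnc(-c2ccccc2Cl)[nH]c1=O`) gives 5 mg/kg, compound 2 (`COc1ccccc1-c1ncc(C(=O)O)c(=O)[nH]1`) gives 10 mg/kg and compound 3 (`CCC(C)Oc1ccccc1-c1ncc(C(=O)O)c(=O)[nH]1`) gives 0.5 mg/kg, the lowest number of the three. Compound 4 (`C[S+]([O-])c1ccccc1-c1ncc(C(=O)O)c(=O)[nH]1`) carries a group of 3 heavy atoms (1 carbon, 1 oxygen, 1 sulfur; no ring) in place of a group of 5 heavy atoms (4 carbon, 1 oxygen; no ring), on an aromatic carbon, on an aromatic carbon ortho to a large group. Within the data shown here, three measured steps bear on this. Sec-butoxy in place of chloro gave a 10-fold lower number from compound 1 to compound 3 (1.00 log units; beyond the scatter), and sec-butyl in place of methyl on the oxygen gave a 20-fold lower number from compound 2 to compound 3 (1.30 log units; beyond the scatter). Methoxy in place of chloro gave a 2.0-fold higher number from compound 1 to compound 2 (0.30 log units; within the scatter), within the scatter. Among the measured compounds shown here, no measured compound carries the entering group, so a return towards the higher numbers is expected, with wide uncertainty. The expected change is a 10-fold higher number from compound 3 to compound 4 (1.00 log units; beyond the scatter). The estimate for compound 4 is 5 mg/kg, with an expected range of 1.5 mg/kg to 20 mg/kg.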

Compound 4, dose for 50% inhibition: > 5 mg/kg
Compound 4 was reported as a limit (the forecaster's own chance of this, stated with the estimate: 5%); the middle value sits exactly at the limit.
By their numbers in this assay, from the lowest: compound 3; then compounds 1 and 2 (each within the scatter of the next).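

A group of 3 heavy atoms (1 carbon, 1 oxygen, 1 sulfur; no ring) in place of a group of 5 heavy atoms (4 carbon, 1 oxygen; no ring), on an aromatic carbon, gives an at least 10-fold higher number from compound 3 to compound 4 (1.00 log units; beyond the scatter). Compound 4 is recorded only as a limit, > 5 mg/kg. The low number of compound 3 therefore does not survive this change, and among the groups shown at this place only sec-butoxy reaches it.

The same group in place of one chlorine atom gives a number no lower from compound 1 to compound 4 (the limit leaves the size open). As far as these compounds go, the step from compound 2 to compound 4 cannot be read, and how far compound 4 lies past its limit stays open. From the compounds shown here alone, whether a longer chain on the oxygen or an amine at this place would keep the low number also remains open.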